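A few compounds are considered here, and "the series" means these few. Any claim that something is new, unique, unknown or untested is made for them only; others in the source may bear on it.

Compound 2 `COc1cccc(/C=C/C(=O)c2ccc(OCCCN3C(=O)/C=C/C(C)(C)C/C=C(\C)CC/C=C/3C)cc2)c1` gives 1.38 ug/mL in a functional assay on HepG2 cells (Homo sapiens) for antiproliferative activity (on this read-out lower numbers stand for stronger inhibition and higher numbers for weaker inhibition), and compound 1 `C/C1=C\CC(C)(C)/C=C/C(=O)N(Cc2cn(CCOc3ccc(C(=O)/C=C/c4ccc(C)cc4)c(O)c3)nn2)/C(C)=C/CC1` gives 0.87 ug/mL in this assay, the two numbers lying within the usual scatter of each other. Compound 3 `COc1cc(/C=C/C(=O)c2ccc(OCCCN3C(=O)/C=C/C(C)(C)C/C=C(\C)CC/C=C/3C)cc2)cc(OC)c1OC` differs from compound 2 by 3,4,5-trimethoxyphenyl in place of 3-methoxyphenyl on a double-bonded chain carbon bound to a double-bonded chain carbon. Among the measured compounds shown here, no measured pair shows the effect of this change, so a small step is expected, in either direction, likely not beyond the scatter. Compound 3 is therefore estimated at 1 ug/mL, with a range from 0.4 ug/mL to 3 ug/mL. The expected step is a 1.4-fold lower number from compound 2 to compound 3 (0.14 log units; within the scatter).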

Compound 3, half-maximal inhibitory concentration: 0.99 ug/mL
Compound 3: middle estimate off by 1.0-fold (0.00 log units), on the high side; measured number inside the range.
By their numbers in this assay, from the lowest: compounds 1, 3 and 2 (each within the scatter of the next).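

In this assay, 3,4,5-trimethoxyphenyl in place of 3-methoxyphenyl on a double-bonded chain carbon bound to a double-bonded chain carbon gives a 1.4-fold lower number from compound 2 to compound 3 (0.14 log units; within the scatter), the first measured view of a change at this position. The larger group, with 12 heavy atoms against 8 and 3 hydrogen-bond acceptors against 1, leaves the number within the scatter. Nothing at hand bears on why this step is so small. Going by these compounds, whether an amine or a carboxylic acid on this phenyl ring would also stay within the scatter remains open.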